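Swapping Bromo for Phenyl on Two Related Cores

The compounds below may be only part of what the source reports. "The series", "measured", "known", "first", "only" and "open" are said of these compounds alone.

Compound 1 `O=C(N1CCC=C[C@@H]1COCc1ccccc1)n1cc(-c2ccc(-c3ccccc3)cc2)nn1` and compound 2 `O=C(N1CCC=C[C@@H]1COCc1ccccc1)n1cc(-c2ccc(Br)cc2)nn1` share one core and differ in a single place: phenyl in place of bromo on an aromatic carbon. In an assay on HEK293 cells for inhibition of diacylglycerol lipase-alpha (Homo sapiens), read by colorimetric assay, with stated times of 30 min, 60 s and 20 min (a higher number here means a weaker inhibitor, a lower number a stronger inhibitor), compound 2 gives 15.9 nM. In this assay compound 1 gives 25.1 nM. The step between them, a 1.6-fold higher number from compound 2 to compound 1 (0.20 log units; within the scatter), is small enough that the two values cannot be told apart with confidence.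

Compound 3 `O=C(N1CCC=C[C@@H]1COCc1ccccc1)n1ccc(-c2ccc(Br)cc2)n1` carries the same bromo-bearing ring on a second core; the difference between the two cores is not broken down here. In this assay compound 3 reaches only a limit, > 10000 nM. That value is a limit of the assay and not a number (the limit of > 10000 nM in this assay, at which 1 of the 3 values shown sits).

Compound 4 `O=C(N1CCC=C[C@@H]1COCc1ccccc1)n1ccc(-c2ccc(-c3ccccc3)cc2)n1` has not yet been measured. It stands to compound 3 as compound 1 stands to compound 2: phenyl in place of bromo on an aromatic carbon. The surroundings of the change are described in the same words in both pairs, so this is the same change made a second time. Because the first instance produced only a 1.6-fold higher number from compound 2 to compound 1 (0.20 log units; within the scatter), the expectation is that compound 4 will behave much like compound 3 and again sit at or beyond the limit. The expected step is a step that the limit leaves unreadable from compound 3 to compound 4, resting on that earlier step. For compound 4 the estimate in this assay is 20000 nM, expected to fall between 8000 nM and 60000 nM.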

Compound 4, half-maximal inhibitory concentration: > 10000 nM
Compound 4 gave a limit, no number (the forecaster's own chance of this, stated with the estimate: 85%); the middle value does not contradict the limit.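

In this assay, among these compounds, compound 3 and compound 4 both end at a limit of the assay and not at a number, so no step between the two can be read: the limit of > 10000 nM in this assay, at which 2 of the 4 values shown sit.

The compounds shown leave open how far each of the two lies past that limit, and so whether phenyl in place of bromo on an aromatic carbon makes any difference on this second core.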